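The source may hold more compounds than are shown below. What is called first, only, known or untested is meant among the compounds shown, and "the series" means these compounds.

Measured in a functional assay on MCF7 cells (Homo sapiens) for inhibition, read by MTT assay, with a stated time of 24 h; on this read-out lower numbers stand for stronger inhibition of growth and higher numbers for weaker inhibition of growth:
- compound 1 `COc1cc(C(=O)n2c(-c3cn(C)c4ccccc34)nc3ccccc32)cc(OC)c1OC`: 5400 nM
- compound 2 `COc1ccc2c(c1)c(-c1nc3ccccc3n1C(=O)c1cc(OC)c(OC)c(OC)c1)cn2C`: 5100 nM
- compound 3 `COc1ccc(C(=O)n2c(-c3cn(C)c4ccc(Br)cc34)nc3ccccc32)cc1OC`: 11300 nM

Of these three, compound 3 has the highest number, 11300 nM, and so shows the weakest growth inhibition. The next compound, compound 4 `COc1cc(C(=O)n2c(-c3cn(C)c4ccc(Br)cc34)nc3ccccc32)cc(OC)c1OC`, has not yet been measured. It comes from compound 3 by one change: methoxy in place of hydrogen on an aromatic carbon.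

Within the data shown here, the only measured step of this kind, a 1.1-fold lower number from compound 1 to compound 2 (0.02 log units; within the scatter), stays within the scatter. However, it sits at a different place in the structure, so it offers only weak guidance. Unlike compound 3, compound 1 already carries the added methoxy, but it has no bromine, and it gives 5400 nM. That comparison mixes two differences and cannot separate them, but it leans towards a lower number.

A modest drop is therefore expected, possibly no larger than the scatter. The estimated change is a 1.5-fold lower number from compound 3 to compound 4 (0.18 log units; within the scatter). Compound 4 is expected to give about 7500 nM, with an estimated range from 3500 nM to 15000 nM.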

Compound 4, concentration for 50% growth inhibition: 9700 nM
Compound 4: the middle estimate sits 1.3-fold (0.11 log units) below what was measured; low and high end bracket the measured number.
By their numbers in this assay, from the lowest: compounds 2, 1, 4 and 3 (each within the scatter of the next, the first and the last beyond it).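

In this assay, the added methoxy, ortho to one methoxy group and meta to another, stays within the scatter on the bromo-bearing core, with a 1.2-fold lower number from compound 3 to compound 4 (0.07 log units; within the scatter). This change has now been seen on two cores, and the two steps agree: the same change on two cores in this assay, a 1.1-fold lower number (0.02 log units; within the scatter) from compound 1 to compound 2 and a 1.2-fold lower number (0.07 log units; within the scatter) from compound 3 to compound 4, 1.1-fold (0.04 log units) apart, within the scatter of two such steps. Bromo also leaves compound 4 within the scatter of both bromine-free compounds, with a 1.8-fold higher number from compound 1 to compound 4 (0.25 log units; within the scatter) and a 1.9-fold higher number from compound 2 to compound 4 (0.28 log units; within the scatter), so these three compounds cannot be told apart here.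

As far as these compounds go, only hydrogen and methoxy are compared at this ring position, so it remains open whether an amine, a carboxylic acid or a longer chain such as ethoxy would move the number beyond the scatter. From the compounds shown here alone, it is also open whether this flat result holds in other cell lines or at other exposure times.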